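Swapping the saturated amine on the shared core

The source may hold more compounds than are shown below. What is called first, only, known or untested is meant among the compounds shown, and "the series" means these compounds.

Compound 1, `COc1cc[nH]c1/C=C1\C(=O)Nc2ccc([N+](=O)[O-])c(N3CC[C@H](O)C3)c21`, gives 104 nM in a functional assay on MDA-MB-435 cells (Homo sapiens) for antiproliferative activity, read by MTT assay, with a stated time of 5 days; a higher number here means a weaker inhibitor, a lower number a stronger inhibitor.
Compound 2, `COc1cc[nH]c1/C=C1\C(=O)Nc2ccc(F)cc21`, gives only a limit in this assay, > 30000 nM.

Going by the values given here, of the two compounds measured so far, compound 1 is the one that gives a number at all; the value for compound 2 is a limit of this assay and not a number, so no step between them can be sized. The limit itself is recorded as the limit of > 30000 nM in this assay, at which 1 of the 2 values shown sits. The two structures differ in more than one place, so what their values show is simply that compound 1 is the active one.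

Compound 3, `COc1cc[nH]c1/C=C1\C(=O)Nc2ccc([N+](=O)[O-])c(N3CCC(N)CC3)c21`, has not yet been measured. It is built from compound 1 by a single change on the shared core, (4-aminopiperidin-1-yl in place of 3-hydroxypyrrolidin-1-yl on an aromatic carbon). The group that enters has the same count of hydrogen-bond donors and acceptors as the one that leaves, with one more heavy atom and a six-membered ring in place of a five-membered one. Among the compounds with values here, no measured pair here shows the effect of such a swap. The step from compound 1 to compound 3 is therefore expected to be small, a 1.1-fold higher number from compound 1 to compound 3 (0.02 log units; within the scatter), not clearly beyond the scatter in either direction. Compound 3 is expected to give about 110 nM in this assay, within 30 nM to 450 nM.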

Compound 3, half-maximal inhibitory concentration: < 10 nM
Compound 3 gave a limit, no number; the forecaster's own chance of this, stated with the estimate: 5%; middle value at least 11-fold (1.04 log units) away from the limit.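

Going by these compounds alone, on the shared core, at this aromatic carbon ortho to a nitro group, 4-aminopiperidin-1-yl in place of 3-hydroxypyrrolidin-1-yl gives an at least 10-fold lower number from compound 1 to compound 3 (1.01 log units; beyond the scatter) in this assay, the first sized step at this position, and it shows that activity here depends on which saturated amine is attached, even though the two groups have the same count of hydrogen-bond donors and acceptors. The value for compound 3 is a limit of the assay and not a number, so the full size of the step stays unknown: the limit of < 10 nM in this assay, at which 1 of the 3 values shown sits.

This single change alters several things at once: the ring goes from five-membered to six-membered, an amino group replaces the hydroxyl, and the defined stereocentre is lost, so the step cannot be assigned to any one of them.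

The compounds shown leave open how a 4-hydroxypiperidin-1-yl or a 3-aminopyrrolidin-1-yl group on the same carbon would compare, and either would separate ring size from the exchange of hydroxyl for amino. They also leave open whether an open-chain amine such as dimethylamino, or a piperazin-1-yl ring, would fit the same trend.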